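The source may hold more compounds than are shown below. What is called first, only, known or untested is meant among the compounds shown, and "the series" means these compounds.

Going by the values given here, compound 1 `COc1cccc(-c2cc(C)c3ncc(CSCCc4ccccc4)n3c2)c1` is the only compound in this set with a plain number in an ADME assay on HEL cells (Homo sapiens) for cytotoxicity, with a stated time of 3 days (a lower number here means that less compound is tolerated, a higher number that more compound is tolerated), where compound 1 gives 20 ug/mL. Compound 2 `Cc1cc(I)c2ncc(CSCCc3ccccc3)n2c1` is the other measured compound. In this assay compound 2 reaches only a limit of the assay, >= 4 ug/mL, so it yields no number to compare with. This is the limit of >= 4 ug/mL in this assay, at which 1 of the 2 values shown sits, at which one of the two values shown sits. Among the compounds with values here, no step between two measured compounds differing in one place is available, so no measured step can guide the next comparison. Compound 3 `Cc1cc(-c2ccccc2O)cn2c(CSCCc3ccccc3)cnc12` differs from compound 1 by 2-hydroxyphenyl in place of 3-methoxyphenyl on an aromatic carbon. Within the data shown here, with no measured step to lean on, a step in this assay from compound 1 to compound 3 of no change at the digits printed from compound 1 to compound 3 (within the scatter) is expected, that is none beyond the usual scatter, in either direction. Compound 3 is therefore estimated to give 20 ug/mL in this assay, with an expected range from 7 ug/mL to 50 ug/mL.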

Compound 3, minimum cytotoxic concentration: 100 ug/mL
For compound 3 the middle estimate is 5.0-fold (0.70 log units) below the measured one, outside the stated range (above it).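

In this assay, replacing 3-methoxyphenyl with 2-hydroxyphenyl on this aromatic carbon, two atoms from the ring nitrogen, gives a 5.0-fold higher number from compound 1 to compound 3 (0.70 log units; beyond the scatter). Going by these compounds alone, this is the first measured step in the set, and it shows that the value at this position depends on the aryl group it carries, with more compound tolerated when 2-hydroxyphenyl is present. Nothing given here accounts for this step.

The single step changes both the oxygen-bearing group, from methoxy to hydroxy, and its place on the phenyl ring, so the compounds shown do not tell which of the two matters. Also open, as far as these compounds go, is how the same position would respond to a 3-hydroxyphenyl or 2-methoxyphenyl group, or to a phenyl ring carrying an amine or a carboxylic acid.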